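The source may report more compounds than this note shows. Statements on the series, on what has been measured and on what is new or still open speak of the compounds shown alone.

Measured compounds:
compound 1, `O=C1C[C@@H]2O[C@@H]([C@H](O)c3ccccc3)[C@@H](O)[C@@H]2O1` — 4380 nM
compound 2, `O=C1C[C@H]2O[C@H]([C@@H](O)c3ccccc3)[C@H](O)[C@H]2O1` — 890 nM
compound 3, `O=C(/C=C/c1ccccc1)O[C@H](c1ccccc1)[C@H]1O[C@@H]2CC(=O)O[C@@H]2[C@H]1O` — 11300 nM

In a functional assay on HeLa cells (Homo sapiens) for cytotoxicity, read by MTT assay, with a stated time of 72 h (a higher number here means a weaker inhibitor, a lower number a stronger inhibitor), compound 3 gives 11300 nM, the highest of the three numbers. Its nearest neighbour is compound 1, which in this assay gives 4380 nM, and the furthest is compound 2, which in this assay gives 890 nM. The step to compound 4, `O=C(/C=C/c1ccccc1)O[C@@H](c1ccccc1)[C@@H]1O[C@H]2CC(=O)O[C@H]2[C@@H]1O`, keeps every atom and bond: the two compounds have the same atoms and bonds and differ only in configuration as drawn: 5 of 6 stereo elements differ; a stereocentre at a saturated chain carbon is drawn R in compound 3 and S in compound 4; a stereocentre at a saturated ring carbon is drawn S in compound 3 and R in compound 4; a stereocentre at a saturated ring carbon is drawn R in compound 3 and S in compound 4; a stereocentre at a saturated ring carbon is drawn R in compound 3 and S in compound 4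

Among the compounds with values here, one measured step bears on this change. Compounds 1 and 2 also share all atoms and bonds, and the step between them is a 4.9-fold lower number from compound 1 to compound 2 (0.69 log units; beyond the scatter), a shift that rests on (the fact that compounds 1 and 2 differ only in the configuration as drawn). Within the data shown here, that precedent suggests that inverting the configuration of compound 3 should likewise move the number downward in this assay by a modest amount, beyond the scatter, though the cinnamate ester that compound 3 and compound 4 carry has no counterpart in that pair, so the size is uncertain.

Compound 4 is therefore expected to give 2400 nM in this assay, within a range from 800 nM to 7500 nM. The estimated step from compound 3 to compound 4 is a 4.7-fold lower number from compound 3 to compound 4 (0.67 log units; beyond the scatter).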

Compound 4, half-maximal inhibitory concentration: 1180 nM
The estimate for compound 4 lay 2.0-fold (0.31 log units) above the measured number, within the range that was stated.
By their numbers in this assay, from the lowest: compounds 2 and 4 (each within the scatter of the next); then compound 1; then compound 3.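

In this assay, the inversion that lowered the number in the pair without the ester, a 4.9-fold lower number from compound 1 to compound 2 (0.69 log units; beyond the scatter), does so again with the cinnamate ester in place, with a 9.6-fold lower number from compound 3 to compound 4 (0.98 log units; beyond the scatter), so the direction of the step holds in a second pair. The ester also reads differently in the two configurations: compound 4 at 1180 nM and compound 2 at 890 nM stand within the scatter of each other, whereas compound 3 at 11300 nM lies apart from compound 1 at 4380 nM. The second pair rests on the same kind of difference as the first: the fact that compounds 3 and 4 differ only in the configuration as drawn

The stereocentres change together in both pairs, so these compounds do not tell which of them carries the step. Going by these compounds, it also remains open whether the same dependence on configuration would hold with an acetate ester in place of the cinnamate, or with an amine in place of the free hydroxyl.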